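A furan-3-yl nucleoside set beside three inactive phenyl analogues

The source may report more compounds than this note shows. Statements on the series, on what has been measured and on what is new or still open speak of the compounds shown alone.

Compound 1, `COc1nc(N)nc2c1c(-c1ccccc1)cn2[C@@H]1O[C@H](CO)[C@@H](O)[C@H]1O`: in a functional assay on HeLa S3 cells (Homo sapiens) for antiproliferative activity, read by XTT assay, with a stated time of 72 h (on this read-out higher numbers stand for weaker inhibition and lower numbers for stronger inhibition), compound 1 gives > 20000 nM, which is a limit of the assay and not a number.
Compound 2, `Nc1nc(N)c2c(-c3ccccc3)cn([C@@H]3O[C@H](CO)[C@@H](O)[C@H]3O)c2n1`: in this assay compound 2 gives > 20000 nM, again a limit rather than a number.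
Compound 3, `COc1ncnc2c1c(-c1ccccc1)cn2[C@@H]1O[C@H](CO)[C@@H](O)[C@H]1O`: in this assay compound 3 gives > 20000 nM, once more a limit.

Compound 1 therefore stands nowhere definite on the numbers shown: it is known only as a limit, and so are the two compounds that differ from it in one place. The step that the two limits leave unreadable from compound 1 to compound 2 and the step that the two limits leave unreadable from compound 1 to compound 3 are both unreadable, since every value rests at the limit of > 20000 nM in this assay, at which 3 of the 3 values shown sit. Both of these steps touch the core of compound 1, not the phenyl ring.

Compound 4, `COc1nc(N)nc2c1c(-c1ccoc1)cn2[C@@H]1O[C@H](CO)[C@@H](O)[C@H]1O`, differs from compound 1 by furan-3-yl in place of phenyl on an aromatic carbon. No measured step concerns this position, so nothing among the shown compounds speaks for a change in either direction; the only guide is that every measured compound, whatever its substitution on the core, remains at the limit. Compound 4 is therefore expected to stay in the same region, with an estimated step that the limit leaves unreadable from compound 1 to compound 4 that most likely cannot be read at all. The estimate for compound 4 is 30000 nM, within a range from 8000 nM to 100000 nM.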

Compound 4, half-maximal inhibitory concentration: > 20000 nM
Compound 4: no number, only a limit; the forecaster's own chance of this, stated with the estimate: 85%; the middle value is on the limit's open side.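

Compound 4, like compound 1, is known only as a limit of the assay and not as a number, so the change from phenyl to furan-3-yl cannot be read: the limit of > 20000 nM in this assay, at which 4 of the 4 values shown sit.

The compounds shown leave open whether any group at this position, on any version of the shared core, would give a readable value in this assay.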